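The compounds below may be only part of what the source reports. "The series", "measured", "known", "first", "only" and "open" are said of these compounds alone.

Measured compounds:
- Compound 1 `Cc1cc(S(=O)(=O)/N=C(\N)n2nccc2-c2ccccc2)c(SCc2ccccc2)cc1Cl`, 0.0772 h
- Compound 2 `Cc1cc(-c2ccccc2)n(/C(N)=N/S(=O)(=O)c2cc(C)c(Cl)cc2SCc2ccccc2C)n1`, 0.154 h
- Compound 3 `Cc1cc(S(=O)(=O)/N=C(\N)n2nccc2-c2ccccc2)c(SCc2cccc3ccccc23)cc1Cl`, 0.268 h

In an ADME assay on microsomes from liver (Homo sapiens) for metabolic stability, read by LC-MS, using NADPH, tested at 5 uM (a lower number here means that the compound disappears faster, a higher number that the compound lasts longer), compound 3 gives the highest of the three numbers; compound 2 lies closest to it, within the scatter, while compound 1 lies furthest, beyond the scatter. Among the measured compounds shown here, the step of a 3.5-fold higher number from compound 1 to compound 3 (0.54 log units; beyond the scatter) is the one measured change that bears on the next compound, since it covers the same place on the structure.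

Compound 4 `Cc1cc(S(=O)(=O)/N=C(\N)n2nccc2-c2ccccc2)c(SCc2ccccc2C)cc1Cl` is not yet measured. It differs from compound 3 by 2-methylphenyl in place of naphthalen-1-yl on a saturated chain carbon bound to a sulfur. This removes the group that gave the rise from compound 1 to compound 3 and puts in its place a group that is carried, on a differently arranged core, by compound 2. Compound 2 and compound 1 both sit below compound 3, so the account expects the step of a 1.8-fold lower number from compound 3 to compound 4 (0.25 log units; within the scatter) to run downward, but by less than the step from compound 1 to compound 3, and possibly within the scatter. Compound 4 is therefore estimated at 0.15 h, with a range from 0.07 h to 0.32 h.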

Compound 4, half-life: 0.0802 h
Compound 4: the middle estimate sits 1.9-fold (0.27 log units) above what was measured, within the range that was stated.
By their numbers in this assay, from the lowest: compounds 1, 4, 2 and 3 (each within the scatter of the next, the first and the last beyond it).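

In this assay, 2-methylphenyl on a saturated chain carbon bound to a sulfur does not keep what naphthalen-1-yl gave, the record showing a 3.3-fold lower number from compound 3 to compound 4 (0.52 log units; beyond the scatter) at this place. Set against phenyl, the same group gives a 1.0-fold higher number from compound 1 to compound 4 (0.02 log units; within the scatter) and so cannot be told apart from it, which leaves naphthalen-1-yl as the only one of the three groups here beyond the scatter of phenyl. Hydrogen in place of methyl on an aromatic carbon reads as a 1.9-fold lower number from compound 2 to compound 4 (0.28 log units; within the scatter) and also stays within the scatter.

From the compounds shown here alone, whether an amine, a carboxylic acid or a longer chain at this place would hold the higher number remains open. No measurement shown here accounts for any of these steps.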